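The source may report more compounds than this note shows. Statements on the series, on what has been measured and on what is new or still open speak of the compounds shown alone.

Measured compounds and their values:
compound 1, `CCOC(=O)c1csc2nc(CN3CCN(Cc4ccccc4)CC3)c(-c3ccc(OC)cc3)n12`, 17100 nM;
compound 2, `CCOC(=O)c1csc2nc(CN3CCN(Cc4ccccc4)CC3)c(-c3ccc(Br)cc3)n12`, 51400 nM;
compound 3, `COc1ccc(-c2cnc3scc(C(=O)NNC(C)=O)n23)cc1`, 8360 nM.

All three were tested in a functional assay on MCF7 cells (Homo sapiens) for antiproliferative activity, read by MTT assay, with a stated time of 72 h; on this read-out higher numbers stand for weaker inhibition and lower numbers for stronger inhibition. Compound 1 and compound 2 share one core and differ in one place, (bromo in place of methoxy on an aromatic carbon), which gave a 3.0-fold higher number from compound 1 to compound 2 (0.48 log units; beyond the scatter). Compound 3 has a different core; the difference between the two cores is not broken down here. In this assay compound 3 gives the lowest of the three numbers, and its gap to compound 1 is beyond the scatter.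

Compound 4, `CC(=O)NNC(=O)c1csc2ncc(-c3ccc(Br)cc3)n12`, has not yet been measured. It differs from compound 3 by bromo in place of methoxy on an aromatic carbon, which is the same change as that from compound 1 to compound 2, at the same place on the ring. The expectation for compound 4 rests on the step from compound 1 to compound 2, a 3.0-fold higher number from compound 1 to compound 2 (0.48 log units; beyond the scatter), and on the value of compound 3, 8360 nM. The step from compound 3 to compound 4 is therefore estimated at a 3.0-fold higher number from compound 3 to compound 4 (0.48 log units; beyond the scatter). On that basis compound 4 is expected to give about 25000 nM in this assay, with a plausible range from 10000 nM to 65000 nM.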

Compound 4, half-maximal inhibitory concentration: 1830 nM
Compound 4: middle estimate off by 14-fold (1.14 log units), on the high side, outside the stated range (below it).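

In this assay, bromo in place of methoxy gave a 4.6-fold lower number from compound 3 to compound 4 (0.66 log units; beyond the scatter), so on this core the change runs in the opposite direction to the one seen on the core of compound 1. Read side by side, the two results show that the step did not carry from one core to the other: the same change on two cores in this assay, a 3.0-fold higher number (0.48 log units; beyond the scatter) from compound 1 to compound 2 and a 4.6-fold lower number (0.66 log units; beyond the scatter) from compound 3 to compound 4, 14-fold (1.14 log units) apart, beyond the scatter of two such steps. Going by these compounds alone, this does not show which difference between the cores goes with the change of direction, and each core offers only a single pair, so no general rule for either core can be drawn, nor can any cause be assigned.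

The compounds shown leave open whether a chloro or an amino group at the same place on the aromatic ring would follow compound 2 or compound 4 in direction. They also leave open whether swapping the ethyl ester of compound 1 for a carboxylic acid, with the rest of the compound unchanged, would alter the effect of the bromo for methoxy change.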